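A few compounds are considered here, and "the series" means these few. Any claim that something is new, unique, unknown or untested is made for them only; others in the source may bear on it.

Series notes. In a functional assay on K562 cells (Homo sapiens) for antiproliferative activity, read by CCK-8 assay, with a stated time of 72 h (a higher number here means a weaker inhibitor of growth, a lower number a stronger inhibitor of growth), compound 2 `CCCCNS(=O)(=O)c1ccc(Nc2ncc3c(n2)N(C2CCCC2)[C@H](CC)C(=O)N3C)cc1` gives 412 nM. Compound 3 `CCNC(=O)c1ccc2c(ccn2-c2ncc3c(n2)N(C2CCCC2)[C@H](CC)C(=O)N3C)c1` gives 428 nM in this assay, a number within the scatter of compound 2, so the two cannot be ordered. Compound 1 `CCC1C(=O)N(C)c2cnc(-n3ccc4cc(C(=O)NCC(C)C)ccc43)nc2N1c1ccn(C)n1` gives 5600 nM in this assay, a higher number than compound 2 by a gap beyond the scatter. Compound 2 thus has the lowest number of the three, with compound 3 alongside it. Compound 4 `CC[C@@H]1C(=O)N(C)c2cnc(Nc3ccc(S(=O)(=O)Nc4ccccc4)cc3)nc2N1C1CCCC1` is not yet measured; it differs from compound 2 by phenyl in place of butyl on a sulfonamide nitrogen. Within the data shown here, no measured pair shows a comparable change, so no direction can be read from the data; the step is expected to be small, likely within the scatter. Compound 4 is estimated at 400 nM, range 150 nM to 1100 nM, an expected step of a 1.0-fold lower number from compound 2 to compound 4 (0.01 log units; within the scatter).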

Compound 4, concentration for 50% growth inhibition: 4180 nM
Beside the measured number, compound 4's estimate is 10-fold (1.02 log units) below it, outside the stated range (above it).
By their numbers in this assay, from the lowest: compounds 2 and 3 (each within the scatter of the next); then compounds 4 and 1 (each within the scatter of the next).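

In this assay, among these compounds, the substituent on the sulfonamide nitrogen is not a silent place: phenyl in place of butyl gives a 10-fold higher number from compound 2 to compound 4 (1.01 log units; beyond the scatter) and is the first single-place change. This step, beyond the scatter, shows that this one change alone can move the number on the shared core. Nothing at hand gives a reason for the step.

Open, from the compounds shown here alone, is whether the higher number follows the aromatic ring or the loss of the chain; cyclohexyl or benzyl on that nitrogen would separate the two. Going by these compounds, whether a shorter methyl or longer hexyl chain stays near compound 2 is also open.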